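A few compounds are considered here, and "the series" means these few. Any claim that something is new, unique, unknown or untested is made for them only; others in the source may bear on it.

Measured compounds:
compound 1, `CC1=C(C(=O)OC(C)(C)C)C(c2cccs2)NC(=O)N1`, 26%
compound 2, `CCN(CC)C(=O)C1=C(C)NC(=O)NC1c1ccoc1`, 15%

In an assay on membranes from CHO cells for displacement of a labelled ligand from adenosine receptor A1 (Homo sapiens), read by scintillation counting, with a stated time of 60 min, tested at 1 uM (on this read-out higher numbers stand for more inhibition at the one concentration tested (going by the name of the read-out) and lower numbers for less inhibition), compound 2 stands lowest of the two numbers shown. Its nearest neighbour is compound 1, whose figure lies higher by an amount beyond the usual scatter of this kind of measurement.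

Compound 3, `CCN(CC)C(=O)C1=C(C)NC(=O)NC1c1cccs1`, has not yet been measured in this assay. It arises from compound 2 by a single change: thiophen-2-yl in place of furan-3-yl on a saturated ring carbon. The ring carbon that carries the group sits next to the ring nitrogen and next to the ring atom that bears a group of 7 heavy atoms, two ring bonds from the ring atom that bears a methyl group. Compound 1 also carries thiophen-2-yl on its core, but it differs from compound 3 in another place as well, so its value can only hint at the direction.

Because compound 1 gives 26% while compound 2 gives 15%, a small upward step is expected from compound 2 to compound 3, of size a number 7 percentage points higher from compound 2 to compound 3 (within the scatter), which stays within the scatter. Compound 3 is therefore estimated at 22% in this assay, with a range from 8% to 38%.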

Compound 3, a percentage reported as inhibition, at one concentration (the size of the read-out at that concentration, not a potency): 13%
Compound 3: middle estimate off by 9 percentage points, on the high side; measured number inside the range.
By their numbers in this assay, from the lowest: compounds 3 and 2 (each within the scatter of the next); then compound 1.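

In this assay thiophen-2-yl in place of furan-3-yl on the saturated ring carbon gives a number 2 percentage points lower from compound 2 to compound 3 (within the scatter) and so, with diethylamino on the carbonyl carbon, these two five-membered aromatic rings cannot be told apart at this position. With thiophen-2-yl held constant, diethylamino in place of tert-butoxy on a carbonyl carbon gives a number 13 percentage points lower from compound 1 to compound 3 (beyond the scatter) and this modest change is the only step shown that lies beyond the scatter. No measurement at hand explains either step.

Going by these compounds, it remains open whether a different group on the saturated ring carbon, such as phenyl or a pyridine ring, would separate from thiophen-2-yl and furan-3-yl. Also open, on these data alone, are the effect of a methoxy group or a secondary amide on the carbonyl carbon, and whether thiophen-2-yl and furan-3-yl would stay level with tert-butoxy in place of diethylamino.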